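A few compounds are considered here, and "the series" means these few. Any claim that something is new, unique, unknown or untested is made for them only; others in the source may bear on it.

Measured compounds:
compound 1, `CN(C)C(=O)CN1CCC(c2cc3c(-c4ccc(=O)n(C5CCOCC5)c4)ccnc3[nH]2)CC1`: 2.3 uL/min
compound 2, `COc1cc(F)ccc1-c1ccnc2[nH]c(C3CCN(CC(=O)N(C)C)CC3)cc12`: 38 uL/min

In an ADME assay on cells (Hepatocyte, Rattus norvegicus) for metabolic stability (on this read-out higher numbers stand for fast clearance and lower numbers for slow clearance), compound 2 holds the higher of the two numbers, and its gap to compound 1 lies beyond the usual scatter. Compound 3, `CC(C)n1cc(-c2ccnc3[nH]c(C4CCN(CC(=O)N(C)C)CC4)cc23)ccc1=O`, differs from compound 2 in one place: a group of 10 heavy atoms (8 carbon, 1 nitrogen, 1 oxygen; one six-membered aromatic ring with 1 hetero atom) in place of a group of 9 heavy atoms (7 carbon, 1 oxygen, 1 fluorine; one six-membered aromatic ring of carbon only), on an aromatic carbon. Going by the values given here, no measured pair shows this exact change, so the direction rests on what the two values show. Because compound 1 gives 2.3 uL/min, the step is expected to run downward, estimated at a 4.8-fold lower number from compound 2 to compound 3 (0.68 log units; beyond the scatter), beyond the scatter. Compound 3 is therefore expected to give about 8 uL/min, plausibly between 3 uL/min and 22 uL/min.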

Compound 3, intrinsic clearance in a liver preparation (reported as CLH), per the amount of preparation that the assay uses: 2.3 uL/min
For compound 3 the middle estimate is 3.5-fold (0.54 log units) above the measured one; measured number below the stated range.
By their numbers in this assay, from the lowest: compounds 1 and 3 (each within the scatter of the next); then compound 2.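

In this assay, 4-fluoro-2-methoxyphenyl gives way on the aromatic carbon opposite the ring nitrogen to an aromatic ring with one hetero atom, and this single change brings a 17-fold lower number from compound 2 to compound 3 (1.22 log units; beyond the scatter) and counts as large. Isopropyl in place of oxan-4-yl on the aromatic nitrogen brings no change at the digits printed from compound 1 to compound 3 (within the scatter) and so leaves the read-out unmoved, which means that the low number holds with either group. From the compounds shown here alone, whether a methyl group on that nitrogen, or a plain phenyl on the aromatic carbon, would give a similar number stays open. No evidence at hand accounts for the large step.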